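This account rests on a few compounds, and the source may have more. Where it says the series, first, only, none or still open, it means among the compounds named here.

Of the compounds shown here, three sharing one core have been measured in an assay on HeLa cells for displacement of a labelled ligand from adenosine receptor A3 (Homo sapiens), read by radioligand binding, with a stated time of 180 min, tested at 1 uM; on this read-out higher numbers stand for more inhibition at the one concentration tested (going by the name of the read-out) and lower numbers for less inhibition. Compound 1, `CC1=C(C(=O)OC(C(F)(F)F)C(F)(F)F)C(c2ccsc2)NC(=O)N1`, gives 8%; compound 2, `CC1=C(C(=O)OC(C(F)(F)F)C(F)(F)F)C(c2ccoc2)NC(=O)N1`, gives 1%; compound 3, `CC(C)OC(=O)C1=C(C(F)(F)F)NC(=O)NC1c1ccco1`, gives 5%. Within the data shown here, the one single-place step among them, a number 7 percentage points lower from compound 1 to compound 2 (within the scatter), changed nothing beyond the scatter. Compound 2 holds the lowest of the three numbers, yet its gaps to compound 3 and to compound 1 both lie within the scatter, so no order among the three can be read from them.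

Compound 4, `CC1=C(C(=O)OCC(F)(F)F)C(c2ccoc2)NC(=O)N1`, differs from compound 2 by hydrogen in place of trifluoromethyl on a saturated chain carbon bound to an oxygen next to a carbonyl group and a saturated chain carbon. Among the measured compounds shown here, no measured step touches this part of the molecule: the step from compound 1 to compound 2 concerns a ring on the core, and compound 3 differs from the others in more than one place, so its value shows only that the core as a whole gives low inhibition. With every measured number low and no step beyond the scatter, compound 4 is expected to remain low, with a number 2 percentage points higher from compound 2 to compound 4 (within the scatter). The estimate for compound 4 in this assay is 3%, in the range -6% to 12%.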

Compound 4, a percentage reported as inhibition, at one concentration (the size of the read-out at that concentration, not a potency): 1%
Compound 4: the middle estimate sits 2 percentage points above what was measured; the measured number falls inside the stated range.
By their numbers in this assay, from the lowest: compounds 2, 4, 3 and 1 (each within the scatter of the next).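

Among these compounds, the replacement of trifluoromethyl by hydrogen on the saturated chain carbon bound to an oxygen next to a carbonyl group and a saturated chain carbon is the first measured step at this place, and in this assay it gives no change at the digits printed from compound 2 to compound 4 (within the scatter). Removing this trifluoromethyl therefore leaves no readable mark on the number, although both compounds sit so low at the one concentration tested that a loss of inhibition could hardly be seen. Nothing available explains this result.

The compounds shown leave open whether an amine, a carboxylic acid or a longer chain at this carbon would raise the number beyond the scatter. They also leave open whether the same replacement would matter with thiophen-3-yl in place of furan-3-yl on the shared core.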